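Methyl to fluoro on the fused ring: clearance notes

The source may hold more compounds than are shown below. What is called first, only, known or untested is meant among the compounds shown, and "the series" means these compounds.

The series shares an amide chain joined through sulfur to a fused two-ring core. Compound 1 `O=C(CCSc1nc2cc(F)c(F)cc2o1)N1CCCC1` carries two fluoro groups on that core; compound 2 `Cc1ccc2oc(SCCC(=O)N3CCCC3)nc2c1` carries a single methyl. In an ADME assay on microsomes from liver (Homo sapiens) for metabolic stability, read by LC-MS, using NADPH, with a stated time of 45 min, tested at 0.5 uM (a higher number here means faster removal of the compound, a lower number slower removal), compound 1 gives 6.5 mL/min/g, and in this assay compound 2 gives 9.3 mL/min/g. Compound 2 stands highest of the two numbers, but its nearest neighbour, compound 1, lies within the usual scatter, so the two cannot be ranked.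

Compound 3 `O=C(CCSc1nc2cc(F)ccc2o1)N1CCCC1` is not yet measured. It differs from compound 2 as follows: fluoro in place of methyl on an aromatic carbon. Within the data shown here, the only guide is that compound 1, bearing fluoro groups, gives 6.5 mL/min/g while compound 2, bearing methyl, gives 9.3 mL/min/g, a gap within the scatter. Accordingly a step of about a 1.2-fold lower number from compound 2 to compound 3 (0.09 log units; within the scatter) is expected, not beyond the scatter. Compound 3 is estimated at 7.5 mL/min/g, with a range of 3.5 mL/min/g to 15 mL/min/g.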

Compound 3, intrinsic clearance in a liver preparation (reported as CLH), per the amount of preparation that the assay uses: 5.2 mL/min/g
Compound 3: the middle estimate sits 1.4-fold (0.16 log units) above what was measured; the measured number falls inside the stated range.
By their numbers in this assay, from the lowest: compounds 3, 1 and 2 (each within the scatter of the next).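

Among these compounds, compound 2 and compound 3 form the first pair that differs in this one place, and in this assay fluoro in place of methyl on an aromatic carbon gives a 1.8-fold lower number from compound 2 to compound 3 (0.25 log units; within the scatter) and so does not separate the two groups. Hydrogen in place of fluoro on an aromatic carbon gives a 1.3-fold lower number from compound 1 to compound 3 (0.10 log units; within the scatter) and so the extra fluoro of compound 1 cannot be told apart from hydrogen at that carbon in this read-out. No measurement at hand bears on what lies behind either step.

On these data alone, whether any group on this ring can shift the clearance beyond the scatter remains open. An amine, a carboxylic acid or a longer chain on the same aromatic carbon would test that question, and the amide chain stays unexplored in the compounds shown.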